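Adding a Second Fluorine: From Compound 3 to Compound 4

This account rests on a few compounds, and the source may have more. Where it says the series, first, only, none or still open, it means among the compounds named here.

Compound 1, `Nc1scc(CN2CCN(c3cc(Cl)cc(Cl)c3)CC2)c1C(=O)c1ccc(Cl)cc1`: -69%
Compound 2, `Nc1scc(CN2CCN(c3ccccc3C(F)(F)F)CC2)c1C(=O)c1ccc(Cl)cc1`: -39%
Compound 3, `Nc1scc(CN2CCN(c3ccccc3F)CC2)c1C(=O)c1ccc(Cl)cc1`: -9.2%

In a functional assay on CHO cells with adenosine receptor A1 (Homo sapiens) as the target, read by cAMP accumulation and immunoassay, with a stated time of 6 min, tested at 1 uM (on this read-out lower numbers stand for a stronger effect and higher numbers for a weaker effect at the one concentration tested), compound 3 gives the highest of the three numbers; compound 2 comes nearest, with a number 29.8 percentage points higher from compound 2 to compound 3 (beyond the scatter), and compound 1 lies furthest, with a number 59.8 percentage points higher from compound 1 to compound 3 (beyond the scatter). Compound 4, `Nc1scc(CN2CCN(c3ccc(F)cc3F)CC2)c1C(=O)c1ccc(Cl)cc1`, differs from compound 3 by fluoro in place of hydrogen on an aromatic carbon. Within the data shown here, no measured step adds a single fluoro to this ring, so the guidance is indirect. Still, both a number 59.8 percentage points higher from compound 1 to compound 3 (beyond the scatter) and a number 29.8 percentage points higher from compound 2 to compound 3 (beyond the scatter) show that the ring bearing more or larger halogen substituents gave the lower number. The expected change is a number 15.8 percentage points lower from compound 3 to compound 4 (beyond the scatter), a modest downward step with wide uncertainty. Compound 4 is therefore expected to give about -25%, most likely between -55% and 5%.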

Compound 4, a percentage reported as activity, at one concentration (the size of the read-out at that concentration, not a potency): -66%
For compound 4 the middle estimate is 41 percentage points above the measured one; measured number outside the range, below it.
By their numbers in this assay, from the lowest: compounds 1 and 4 (each within the scatter of the next); then compound 2; then compound 3.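

In this assay, one fluoro placed para to a large group on the 2-fluorophenyl ring gives a number 56.8 percentage points lower from compound 3 to compound 4 (beyond the scatter) and so shows that this single position can matter greatly. The 2,4-difluorophenyl ring also gives a number 27 percentage points lower from compound 2 to compound 4 (beyond the scatter) and sits level with 3,5-dichlorophenyl in a number 3 percentage points higher from compound 1 to compound 4 (within the scatter) without any chlorine on the ring. The size of the halogen group alone therefore does not order these rings, and compound 2 with its trifluoromethyl goes against that reading. As far as these compounds go, whether chloro, methoxy or an amine at this same position would act like fluoro remains open. Nothing available explains why this one fluoro matters so much.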